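Replacing a dimethoxyphenyl ketone arm with an aminomethylpyrimidine

A few compounds are considered here, and "the series" means these few. Any claim that something is new, unique, unknown or untested is made for them only; others in the source may bear on it.

Compound 1 `COc1ccc(-c2cc3ccccc3nc2/C=C/C(=O)c2c(OC)cccc2OC)cc1` carries a 2,6-dimethoxyphenyl group on the carbonyl carbon of its enone chain. In a functional assay on MDA-MB-231 cells (Homo sapiens) for antiproliferative activity, read by XTT assay, with a stated time of 72 h (on this read-out lower numbers stand for stronger inhibition and higher numbers for weaker inhibition), compound 1 gives 5630 nM, the highest number of the three measured compounds, meaning the weakest inhibition among them. Compound 2 `COc1ccc(-c2cc3ccccc3nc2/C=C/C(=O)c2ccc(OC)c(OC)c2)cc1` gives 4790 nM, and the step of a 1.2-fold lower number from compound 1 to compound 2 (0.07 log units; within the scatter) shows that moving the two methoxy groups around the ring changes little. Compound 3 `COc1ccc(-c2cc3ccccc3nc2/C=C/C(=O)c2ccccn2)cc1` gives 740 nM; here the step of a 7.6-fold lower number from compound 1 to compound 3 (0.88 log units; beyond the scatter) shows that a nitrogen-containing ring in place of the dimethoxyphenyl gives a clearly stronger result, and the step of a 6.5-fold lower number from compound 2 to compound 3 (0.81 log units; beyond the scatter) tells the same story from compound 2.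

Compound 4 `COc1ccc(-c2cc3ccccc3nc2/C=C/C(=O)c2cnc(N)nc2C)cc1` is the next step from compound 1: 2-amino-4-methylpyrimidin-5-yl in place of 2,6-dimethoxyphenyl on a carbonyl carbon. Going by the values given here, the only step that bears on this is the one to compound 3, where a nitrogen-containing six-membered ring on the carbonyl carbon brought a modest gain. The new ring in compound 4 also carries an amino group and a methyl group, for which no measured comparison exists, so the size of the step is uncertain. A gain is therefore expected for compound 4, but smaller or at most similar to that seen for compound 3, which is what the estimated step of a 2.8-fold lower number from compound 1 to compound 4 (0.45 log units; beyond the scatter) means. Compound 4 is expected to give about 2000 nM, plausibly between 500 nM and 7000 nM.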

Compound 4, half-maximal inhibitory concentration: > 10000 nM
Compound 4 gave a limit, no number; the forecaster's own chance of this, stated with the estimate: 5%; middle value at least 5.0-fold (0.69 log units) from the limit.
By their numbers in this assay, from the lowest: compound 3; then compounds 2 and 1 (each within the scatter of the next). At a limit, above all of these: compound 4.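

In this assay compound 4 gives a limit of the assay and not a number: the limit of > 10000 nM in this assay, at which 1 of the 4 values shown sits. This shows that a nitrogen-containing six-membered ring on the carbonyl carbon does not bring a gain by itself: putting 2-amino-4-methylpyrimidin-5-yl in place of pyridin-2-yl gives an at least 13-fold higher number from compound 3 to compound 4 (1.13 log units; beyond the scatter) and loses all of the gain seen earlier. The new ring also shows no gain over either dimethoxyphenyl arm, with an at least 2.0-fold higher number from compound 2 to compound 4 (0.31 log units; beyond the scatter) on one side and an at least 1.7-fold higher number from compound 1 to compound 4 (0.24 log units; that floor lies within the scatter) on the other, so this position tolerates some nitrogen-containing rings far better than others.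

The amino group, the methyl group and the second ring nitrogen all enter together, so the compounds shown cannot say which of them accounts for the loss, nor how far past the limit compound 4 really lies. A plain pyrimidin-5-yl ring, or a pyridin-2-yl ring carrying only an amino group or only a methyl group, would be needed to pull these changes apart.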